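Fluoro for Hydroxy: Expected Toxicity of Compound 4

The source may hold more compounds than are shown below. What is called first, only, known or untested is meant among the compounds shown, and "the series" means these compounds.

Of the compounds shown here, three sharing one core have been measured. Compound 1 `Cc1ccc(S(=O)(=O)NC(=O)Nc2ccccc2C(=O)/C=C/c2ccc(N(C)C)cc2)cc1` gives 38.1 ug/mL in an ADME assay on the whole organism for cytotoxicity, with Artemia salina as the target, with a stated time of 24 h; a higher number here means that more compound is needed for the effect, a lower number that less compound is needed. Compound 2 `CCc1cc(/C=C/C(=O)c2ccccc2NC(=O)NS(=O)(=O)c2ccc(C)cc2)cc(OC)c1OC` gives 19.2 ug/mL, and compound 3 `Cc1ccc(S(=O)(=O)NC(=O)Nc2ccccc2C(=O)/C=C/c2ccc(O)cc2)cc1` gives 24.3 ug/mL. Compound 3 lies close to both neighbours: a 1.3-fold higher number from compound 2 to compound 3 (0.10 log units; within the scatter) and a 1.6-fold lower number from compound 1 to compound 3 (0.20 log units; within the scatter), so none of the three stands apart. Compound 4 `Cc1ccc(S(=O)(=O)NC(=O)Nc2ccccc2C(=O)/C=C/c2ccc(F)cc2)cc1` differs from compound 3 by fluoro in place of hydroxy on an aromatic carbon. For the measured compounds named here, the steps that bear on it, a 2.0-fold lower number from compound 1 to compound 2 (0.30 log units; within the scatter) and a 1.6-fold lower number from compound 1 to compound 3 (0.20 log units; within the scatter), both change the group at the same place and both stay within the scatter. The change to compound 4 is therefore expected to bring no step beyond the scatter, a 1.0-fold higher number from compound 3 to compound 4 (0.01 log units; within the scatter). Compound 4 is estimated at 25 ug/mL, between 10 ug/mL and 60 ug/mL.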

Compound 4, concentration for half-maximal effect: 3.96 ug/mL
Compound 4: the middle estimate sits 6.3-fold (0.80 log units) above what was measured; the whole stated range lies above it.
By their numbers in this assay, from the lowest: compound 4; then compounds 2, 3 and 1 (each within the scatter of the next).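

In this assay, the earlier changes at this place stayed within the scatter, but fluoro in place of hydroxy on the aromatic carbon moves the number beyond it (a 6.1-fold lower number from compound 3 to compound 4 (0.79 log units; beyond the scatter)). The same holds against the other two compounds (a 4.8-fold lower number from compound 2 to compound 4 (0.69 log units; beyond the scatter); a 9.6-fold lower number from compound 1 to compound 4 (0.98 log units; beyond the scatter)), so the group at this place is not indifferent, and compound 4 stands apart from all three. Going by these compounds, whether chloro or trifluoromethyl at this place would follow fluoro or hydroxy remains open. Nothing shown gives a reason for this step.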